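A few compounds are considered here, and "the series" means these few. Any claim that something is new, unique, unknown or untested is made for them only; others in the source may bear on it.

Working notes on the series. Four compounds are in hand. Compound 1 `Cn1c(=O)[nH]c2ccc(OCCc3cccc(Cl)c3)cc21` and compound 3 `Cn1c(=O)[nH]c2ccc(OCCCc3ccccc3)cc21` share one core; compound 2 `Cc1ccc(COc2ccc3c(c2)C(C(C)C)C(=O)N3)cc1` and the not yet measured compound 4 `CC(C)C1C(=O)Nc2ccc(OCc3cccc(F)c3)cc21` share another. In an assay on cells for inhibition of Amine oxidase [flavin-containing] A (Homo sapiens), read by fluorescence, with stated times of 30 min and 15 min (a higher number here means a weaker inhibitor, a lower number a stronger inhibitor), compound 1 gives "not determined" (no result reported). In this assay compound 2 likewise gives "not determined" (no result reported), so no number of its own places compound 2 anywhere on the scale. In this assay compound 3 gives > 500000 nM, which is a limit of the assay and not a number. Where compound 2 stands, then, is told only by what surrounds it: one further value is a limit, one further entry carries no number, and compound 2 itself has none.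

The step from compound 2 to compound 4 is a single exchange, (3-fluorophenyl in place of 4-methylphenyl on a saturated chain carbon bound to an oxygen on an aromatic ring). Going by the values given here, no measured step between any two compounds exists, so the size of this step in this assay cannot be read from the data; the expectation is for no change beyond the scatter, with little to rest it on.

Because the limit of > 500000 nM in this assay, at which 1 of the 3 values shown sits, is the only result that carries any figure, the estimate for compound 4 leans toward weak inhibition, expected at 100000 nM in this assay, within 5000 nM to 500000 nM.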

Compound 4, half-maximal inhibitory concentration: > 500000 nM
Compound 4 gave a limit, no number; the forecaster's own chance of this, stated with the estimate: 55%; at least 5.0-fold (0.69 log units) between middle value and limit.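

In this assay compound 4 gives > 500000 nM, which is a limit of the assay and not a number. Going by these compounds alone, no step from compound 2 to compound 4 can be read, as compound 2 carries no number of its own. The compounds shown leave open where on the scale of this assay any of them stands.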